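From Phenoxy to Phenyl in a Growth Inhibition Series

A few compounds are considered here, and "the series" means these few. Any claim that something is new, unique, unknown or untested is made for them only; others in the source may bear on it.

In a functional assay on DU-145 cells (Homo sapiens) for inhibition, read by trypan blue exclusion, with a stated time of 96 h (on this read-out lower numbers stand for stronger inhibition of growth and higher numbers for weaker inhibition of growth), compound 1 (`COc1ccc(/C=C(/Sc2ccc(C)cc2)C(=O)c2ccc(Br)cc2)cc1`) stands at 50000 nM and compound 2 (`Cc1ccc(S/C(=C/c2ccc(Cl)cc2)C(=O)c2ccc(Br)cc2)cc1`) at 10000 nM while compound 3 (`Cc1ccc(S/C(=C/c2ccc(Oc3ccccc3)cc2)C(=O)c2ccc(Br)cc2)cc1`) reaches 1000 nM as the lowest number of the three. Compound 4 (`Cc1ccc(S/C(=C/c2ccc(-c3ccccc3)cc2)C(=O)c2ccc(Br)cc2)cc1`) differs from compound 3 at one place: phenyl in place of phenoxy on an aromatic carbon (phenyl in place of phenoxy on an aromatic carbon, para to a large group).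

Among the measured compounds shown here, three measured steps concern that same substituent. Chloro in place of methoxy gave a 5.0-fold lower number from compound 1 to compound 2 (0.70 log units; beyond the scatter) and is modest. Phenoxy in place of chloro gave a 10-fold lower number from compound 2 to compound 3 (1.00 log units; beyond the scatter) and is also modest. Phenyl in place of methyl on the oxygen gave a 50-fold lower number from compound 1 to compound 3 (1.70 log units; beyond the scatter) and is large. Among these three compounds the numbers fall from methoxy through chloro to phenoxy, but no measured step exchanges phenoxy for phenyl directly. Compound 4 keeps the outer aromatic ring that compound 3 carries at 1000 nM and lacks only the oxygen, so a small step is expected rather than a loss of the whole gain. The expected step in this assay is a 2.0-fold higher number from compound 3 to compound 4 (0.30 log units; within the scatter) and thus small, toward weaker inhibition. For compound 4 the estimated value is 2000 nM with a range from 500 nM up to 10000 nM expected.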

Compound 4, concentration for 50% growth inhibition: 50000 nM
Compound 4: middle estimate off by 25-fold (1.40 log units), on the low side; the whole stated range lies below it.
By their numbers in this assay, from the lowest: compound 3; then compound 2; then compounds 1 and 4 (each within the scatter of the next).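

In this assay the outer aromatic ring does not by itself account for the gain at this position: phenyl in place of phenoxy gives a 50-fold higher number from compound 3 to compound 4 (1.70 log units; beyond the scatter), although the change removes only the oxygen that links that ring to the core. Phenyl also compares poorly with the smaller chloro, with a 5.0-fold higher number from compound 2 to compound 4 (0.70 log units; beyond the scatter), and set against methoxy it gives no change at the digits printed from compound 1 to compound 4 (within the scatter), so the gain seen among the earlier compounds does not follow simply from placing an aromatic ring on this carbon, and within these four compounds only the ring joined through oxygen reaches the lowest number. Nothing among the data given here explains why removing the oxygen has so large an effect.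

The compounds shown leave open whether the oxygen itself matters or whether another link to the outer ring would serve as well, as a phenylamino group or a benzyl group might show. They also leave open how substituents on the outer ring, such as a fluorine or a carboxylic acid, would affect growth inhibition in this series.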